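A few compounds are considered here, and "the series" means these few. Any claim that something is new, unique, unknown or untested is made for them only; others in the source may bear on it.

In a functional assay on A549 cells (Homo sapiens) for cytotoxicity, read by colorimetric assay and MTT assay, with a stated time of 3 days, tested at 20 uM (on this read-out lower numbers stand for a stronger effect and higher numbers for a weaker effect at the one concentration tested), compound 1 `O=C1COc2ccc(-c3[nH]c(-c4c[nH]c5ncccc45)nc3-c3ccccc3)cc2N1` gives 86.8%, the highest of the two numbers recorded. Compound 2 `O=C1COc2ccc(-c3nn(-c4ccccc4)cc3-c3ccccc3)cc2N1` gives 59.7% in this assay, a number lower than that of compound 1 by more than the usual scatter. Compound 3 `O=C1COc2ccc(-c3[nH]c(-c4ccc(C(F)(F)F)cc4)nc3-c3ccccc3)cc2N1` has not yet been measured. It differs from compound 1 in one place: a group of 10 heavy atoms (7 carbon, 3 fluorine; one six-membered aromatic ring of carbon only) in place of a group of 9 heavy atoms (7 carbon, 2 nitrogen; one five-membered aromatic ring with 1 hetero atom, one six-membered aromatic ring with 1 hetero atom), on an aromatic carbon, on an aromatic carbon between two ring nitrogen atoms of the shared core. Going by the values given here, no step of this kind has been measured, so the expectation rests on the structural change alone; a modest shift downward, of roughly the size of the scatter, is expected in this assay, namely a number 11.8 percentage points lower from compound 1 to compound 3 (beyond the scatter). Compound 3 is therefore estimated at 75%, in a range from 50% to 100%.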

Compound 3, a percentage reported as activity, at one concentration (the size of the read-out at that concentration, not a potency): 21.7%
The estimate for compound 3 lay 53.3 percentage points above the measured number; the measured number lies below the stated range.
By their numbers in this assay, from the lowest: compound 3; then compound 2; then compound 1.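

Within this assay the aromatic carbon between two ring nitrogen atoms proves sensitive to what it carries: 4-(trifluoromethyl)phenyl in place of the group of compound 1 gives a number 65.1 percentage points lower from compound 1 to compound 3 (beyond the scatter) on the side of the stronger effect. The change therefore shows that a six-membered aromatic ring of carbon only, with 0 hydrogen-bond donors and 0 hydrogen-bond acceptors, can stand at this position with a large gain in effect. No evidence bears on the cause of this step. As far as these compounds go, whether the step follows the trifluoromethyl group or the phenyl ring itself stays open, as does how a methoxy group or an amine on that ring would read.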